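Benzyl Group Exchange: Nitro to Methoxy in an Antagonist Series

The compounds below may be only part of what the source reports. "The series", "measured", "known", "first", "only" and "open" are said of these compounds alone.

Measured compounds:
compound 1, `COc1cccc(OC)c1OCCNCCOc1ccccc1OCc1ccccc1C`, 7.81
compound 2, `COc1cccc(OC)c1OCCNCCOc1ccccc1OCc1ccccc1[N+](=O)[O-]`, 8.2
compound 3, `COc1ccc(COc2ccccc2OCCNCCOc2c(OC)cccc2OC)cc1`, not yet measured

In a functional assay on Vas deferens for antagonist activity at Alpha-1A adrenergic receptor (Rattus norvegicus) (a lower number here means a less potent compound, a higher number a more potent compound, by a factor of ten per unit of this negative logarithm), compound 1 gives 7.81 and compound 2 gives 8.2. Compound 2 holds the higher of the two numbers, the step of a number 0.39 log units higher from compound 1 to compound 2 (beyond the scatter) lying beyond the scatter. Compound 3 differs from compound 2 by 4-methoxyphenyl in place of 2-nitrophenyl on a saturated chain carbon bound to an oxygen on an aromatic ring. Among the compounds with values here, the one measured step, a number 0.39 log units higher from compound 1 to compound 2 (beyond the scatter), concerns a different exchange on the same saturated chain carbon and gives only a modest shift, so it bears on the present change indirectly; no measured compound carries a 4-methoxybenzyl group. Compound 3 is therefore expected to land near the two measured numbers, with no step beyond the scatter confidently predicted; the estimated step is a number 0.30 log units lower from compound 2 to compound 3 (within the scatter). The estimate for compound 3 in this assay is 7.9, ranging from 7.3 to 8.5.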

Compound 3, negative logarithm of the antagonist equilibrium constant: 8.54
The estimate for compound 3 lay 0.64 log units below the measured number; the whole stated range lies below it.
By their numbers in this assay, from the lowest: compound 1; then compound 2; then compound 3.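

Exchanging the whole aryl group at this position, on a saturated chain carbon bound to an oxygen on an aromatic ring, does more than keep activity in this assay: 4-methoxyphenyl in place of 2-nitrophenyl gives a number 0.34 log units higher from compound 2 to compound 3 (beyond the scatter), so the nitro group of the earlier pair is not needed for high potency. Against the 2-methylphenyl group, the same 4-methoxyphenyl group gives a number 0.73 log units higher from compound 1 to compound 3 (beyond the scatter), which makes compound 3 the most potent of the three. No measurement at hand offers a reason for this order.

The exchange alters the substituent and its place on the phenyl ring at once, so the compounds cannot show which of the two matters. From the compounds shown here alone, how a plain benzyl group, or a benzyl group bearing an amine, would read in this assay also remains open.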